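The source may hold more compounds than are shown below. What is called first, only, known or untested is meant among the compounds shown, and "the series" means these compounds.

Compound 1 `FC(F)(F)c1ccccc1Cn1cnnc1-c1cccc(Cl)c1Cl`: in a functional assay for antagonist activity at P2X purinoceptor 7 (Homo sapiens) (a lower number here means a stronger inhibitor, a higher number a weaker inhibitor), compound 1 gives 132 nM.
Compound 2 `FC(F)c1ccccc1Cn1cnnc1-c1cccc(Cl)c1Cl`: compound 2 gives 117 nM.
Compound 3 `CSc1ccccc1Cn1cnnc1-c1cccc(Cl)c1Cl`: compound 3 gives 49 nM.

Compound 3 has the lowest of the three numbers in this assay; the step of a 2.4-fold lower number from compound 2 to compound 3 (0.38 log units; beyond the scatter) and the step of a 2.7-fold lower number from compound 1 to compound 3 (0.43 log units; beyond the scatter) are both beyond the scatter, while a 1.1-fold lower number from compound 1 to compound 2 (0.05 log units; within the scatter) lies within it. Compound 4 `CSc1ccccc1Cn1cnnc1-c1cccc(C(F)(F)F)c1Cl` keeps the shared core of compound 3 and alters the other ring: trifluoromethyl in place of chloro on an aromatic carbon. Among the compounds with values here, none of the measured steps touches this change; all three concern the exchange among trifluoromethyl, difluoromethyl and methylsulfanyl, a different group at a different place. Within the data shown here, with no step bearing on it, the expected step of a 1.2-fold higher number from compound 3 to compound 4 (0.09 log units; within the scatter) is small and of no clear direction. Compound 4 is therefore estimated at 60 nM, within a range from 20 nM to 200 nM.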

Compound 4, half-maximal inhibitory concentration: 26.9 nM
Compound 4: the middle estimate sits 2.2-fold (0.35 log units) above what was measured; the range from low to high includes it.
By their numbers in this assay, from the lowest: compounds 4 and 3 (each within the scatter of the next); then compounds 2 and 1 (each within the scatter of the next).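

This is the first change shown on the ring bearing the two chloro groups, and in this assay it gives a 1.8-fold lower number from compound 3 to compound 4 (0.26 log units; within the scatter), a step within the scatter. The place on an aromatic carbon, ortho to a chloro group, therefore takes trifluoromethyl instead of chloro with no step beyond the scatter. Nothing available gives a reason for this result. Still open, as far as these compounds go, is how an amine, a carboxylic acid or a longer chain would read at this place, and whether the same exchange would give a comparable step with the trifluoromethyl of compound 1 or the difluoromethyl of compound 2 on the other ring.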